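Extending the acetyl of compound 3 to (3-aminopropyl)carbonyl

A few compounds are considered here, and "the series" means these few. Any claim that something is new, unique, unknown or untested is made for them only; others in the source may bear on it.

Measured compounds:
compound 1, `CN1CCN(S(=O)(=O)c2ccc(NC(=O)c3ccccc3)c3ccccc23)CC1`: > 30000 nM (a limit)
compound 2, `CCOC(=O)N1CCC(NS(=O)(=O)c2ccc(O)c3ccccc23)CC1`: > 5000 nM (a limit)
compound 3, `CC(=O)N1CCC(NS(=O)(=O)c2ccc(NC(=O)c3ccccc3C)c3ccccc23)CC1`: 6.7 nM

In an assay on L1.2 cells for binding affinity to C-C chemokine receptor type 8 (Homo sapiens) (on this read-out lower numbers stand for stronger inhibition and higher numbers for weaker inhibition), compound 1 reaches only the limit > 30000 nM (the limit of > 30000 nM in this assay, at which 1 of the 3 values shown sits). Compound 2 likewise gives only the limit > 5000 nM (the limit of > 5000 nM in this assay, at which 1 of the 3 values shown sits). For the measured compounds named here, compound 3 gives 6.7 nM in this assay, the only real number among the three. Going by the values given here, since compound 1 and compound 2 each reach only a limit, no measured step between compounds exists, and neither of them can be placed relative to compound 3.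

Compound 4, `Cc1ccccc1C(=O)Nc1ccc(S(=O)(=O)NC2CCN(C(=O)CCCN)CC2)c2ccccc12`, differs from compound 3 by 2-aminoethyl in place of hydrogen on a saturated chain carbon bound to a carbonyl carbon. Among the compounds with values here, no measured pair covers a change of this kind, so the expectation rests on compound 3 alone. The step from compound 3 to compound 4 is expected to be small, at most a modest weakening near the edge of the scatter, estimated as a 2.2-fold higher number from compound 3 to compound 4 (0.35 log units; beyond the scatter). For compound 4 the estimated value in this assay is 15 nM, with a range from 3 nM to 80 nM.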

Compound 4, inhibition constant: 1.6 nM
The estimate for compound 4 lay 9.4-fold (0.97 log units) above the measured number; measured number below the stated range.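

In this assay, for the compounds shown here, the change of acetyl to (3-aminopropyl)carbonyl gives a 4.2-fold lower number from compound 3 to compound 4 (0.62 log units; beyond the scatter), the first measured step. The saturated chain carbon bound to a carbonyl carbon therefore accepts 2-aminoethyl in place of hydrogen, and the affinity seen with acetyl is not only kept but improved by a margin beyond the usual scatter. Nothing measured here bears on the reason for this gain.

Still open, from the compounds shown here alone, is whether the step belongs to the terminal amine or to the added chain alone, a question that a plain propyl in place of 3-aminopropyl would address. Also open, going by these compounds, is how the step responds to a carboxylic acid at the chain end, or to a longer chain that carries the amine.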